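This account rests on a few compounds, and the source may have more. Where it says the series, first, only, none or still open, it means among the compounds named here.

Compound 1, `Cc1ccccc1S(=O)(=O)Nc1ccc2oc(-c3ccccc3)nc2c1`: > 63000 nM
Compound 2, `O=S(=O)(Nc1ccc(-c2nc3ccccc3o2)cc1)c1ccccc1F`: > 63000 nM

Compound 1 is a sulfonamide built on a shared core. In an assay on isolated protein for inhibition of malate dehydrogenase, mitochondrial (Sus scrofa), with stated times of 45 min and 30 min (on this read-out higher numbers stand for weaker inhibition and lower numbers for stronger inhibition), compound 1 gives > 63000 nM, which is a limit of the assay rather than a number. Compound 2 in this assay gives > 63000 nM, also a limit. Both results thus sit at the limit of > 63000 nM in this assay, at which 2 of the 2 values shown sit, so compound 1 cannot be placed higher or lower than the other compound on the numbers shown; the two simply share the same limit. Compound 3, `O=S(=O)(Nc1ccc2oc(-c3ccccc3)nc2c1)c1ccc(O)cc1`, has not yet been tested. It differs from compound 1 in one place: 4-hydroxyphenyl in place of 2-methylphenyl on a sulfonyl sulfur. Within the data shown here, no measured step between two compounds is available here, so the effect of this change can only be guessed. Given that compound 1 sits at the limit of > 63000 nM in this assay, at which 2 of the 2 values shown sit, compound 3 is expected to remain near that limit, the step that the limit leaves unreadable from compound 1 to compound 3 being expected to mean little beyond the scatter. Compound 3 is estimated at 70000 nM, within 20000 nM to 250000 nM.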

Compound 3, half-maximal inhibitory concentration: > 63000 nM
Compound 3: only a limit was reported; the forecaster's own chance of this, stated with the estimate: 75%; the middle value is on the limit's open side.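

Compound 3, like compound 1, gives only a limit, so the step between these two compounds cannot be read: (the limit of > 63000 nM in this assay, at which 3 of the 3 values shown sit). The compounds shown leave open whether any change on the shared core gives a result in this assay that is a number rather than a limit.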